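The source may report more compounds than this note shows. Statements on the series, on what has been measured and on what is new or still open speak of the compounds shown alone.

Compound 2, `COc1cc2nc(N3CCN(S(=O)(=O)c4cc(C(=O)O)c(Cl)cc4Cl)CC3)nc(N)c2cc1OC`, gives 52000 nM in a functional assay on PC-3 cells (Homo sapiens) for inhibition; on this read-out lower numbers stand for stronger inhibition and higher numbers for weaker inhibition; it holds the highest of the two numbers recorded, with compound 1 nearest. For the measured compounds named here, compound 1, `COc1cc2nc(N3CCN(S(=O)(=O)c4ccc(C(F)(F)F)cc4)CC3)nc(N)c2cc1OC`, gives 27000 nM in this assay, and a 1.9-fold higher number from compound 1 to compound 2 (0.28 log units; within the scatter) is the only measured step. Compound 3, `COc1cc2nc(N3CCN(S(=O)(=O)c4cccc5ccccc45)CC3)nc(N)c2cc1OC`, differs from compound 2 by naphthalen-1-yl in place of 5-carboxy-2,4-dichlorophenyl on a sulfonyl sulfur. Going by the values given here, no measured step covers this exchange; the one step that changes the same aryl group stayed within the scatter, so no change beyond the scatter is expected, a 1.7-fold lower number from compound 2 to compound 3 (0.24 log units; within the scatter). Compound 3 is therefore estimated at 30000 nM, within 10000 nM to 90000 nM.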

Compound 3, half-maximal inhibitory concentration: 14000 nM
The estimate for compound 3 lay 2.1-fold (0.33 log units) above the measured number, and the stated range covers the measured number.
By their numbers in this assay, from the lowest: compounds 3, 1 and 2 (each within the scatter of the next, the first and the last beyond it).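

Naphthalen-1-yl on the sulfonyl sulfur gives the first change beyond the scatter at this position in this assay (a 3.7-fold lower number from compound 2 to compound 3 (0.57 log units; beyond the scatter)). Against 4-(trifluoromethyl)phenyl the same group stays within the scatter (a 1.9-fold lower number from compound 1 to compound 3 (0.29 log units; within the scatter)), so the separation holds only against 5-carboxy-2,4-dichlorophenyl. Nothing measured here accounts for this step.

On these data alone, the carboxy and dichloro parts of 5-carboxy-2,4-dichlorophenyl change together, so their separate contributions remain open. Also open, as far as these compounds go, is how a benzyl group or an aminophenyl group would read on the sulfonyl sulfur.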